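The source may hold more compounds than are shown below. What is called first, only, known or untested is meant among the compounds shown, and "the series" means these compounds.

Compound 3 `CNC(=O)c1c(Nc2ccc(I)cc2Cl)sc2c1CC(C)(C)CNC2=O` is one of three analogues built on a shared core, alongside compound 1 `CCOC(=O)c1c(Nc2ccc(I)cc2F)sc2c1CC(C)(C)CNC2=O` and compound 2 `CC1(C)CNC(=O)c2sc(Nc3ccc(I)cc3Cl)c(C(N)=O)c2C1`. In a functional assay on HT-29 cells (Homo sapiens) for antiproliferative activity (on this read-out lower numbers stand for stronger inhibition and higher numbers for weaker inhibition), compound 1 gives "not determined" (no result reported). Compound 2 gives 596 nM in this assay, and compound 3 gives 1630 nM, so compound 3 carries the highest of the two numbers available, its nearest neighbour being compound 2, which lies a 2.7-fold higher number from compound 2 to compound 3 (0.44 log units; beyond the scatter) apart from it in this assay.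

Compound 4 `CC1(C)CNC(=O)c2sc(Nc3ccc(I)cc3Cl)c(C(=O)NC[C@@H](O)CO)c2C1` departs from compound 3 in one place: 1,2-dihydroxyethyl in place of hydrogen on a saturated chain carbon bound to an amide-type nitrogen. Among the compounds with values here, the only measured step that touches this region is a 2.7-fold higher number from compound 2 to compound 3 (0.44 log units; beyond the scatter), a modest weakening when a small group was placed on the amide-type nitrogen. That step does not say how a longer, hydroxyl-bearing chain will behave, so for compound 4 the expectation is a step of a 1.5-fold lower number from compound 3 to compound 4 (0.17 log units; within the scatter), likely within the scatter, with a wide uncertainty in either direction. Compound 4 is therefore estimated at 1100 nM in this assay, within a range from 300 nM to 4000 nM.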

Compound 4, half-maximal inhibitory concentration: 710 nM
The estimate for compound 4 lay 1.5-fold (0.19 log units) above the measured number, and the stated range covers the measured number.
By their numbers in this assay, from the lowest: compounds 2 and 4 (each within the scatter of the next); then compound 3.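

Extending the methyl of compound 3 to the 2,3-dihydroxypropyl chain of compound 4 gives a 2.3-fold lower number from compound 3 to compound 4 (0.36 log units; beyond the scatter) in this assay and so shows that a larger group on this amide-type nitrogen can reverse the weakening seen with methyl, which was a 2.7-fold higher number from compound 2 to compound 3 (0.44 log units; beyond the scatter) on the same nitrogen. Compared with the unsubstituted amide, the chain gives a 1.2-fold higher number from compound 2 to compound 4 (0.08 log units; within the scatter) and leaves compound 2 and compound 4 indistinguishable, so among these compounds a substituent on this nitrogen does not in itself cost activity. Nothing shown here gives a reason for the difference between the methyl and the 2,3-dihydroxypropyl chain.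

Whether the hydroxyl groups matter remains open, since a plain propyl chain does not appear among these compounds. The compounds shown also leave open how the opposite stereocentre, a terminal amine or a carboxylic acid would behave on this chain.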